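A few compounds are considered here, and "the series" means these few. Any claim that something is new, unique, unknown or untested is made for them only; others in the source may bear on it.

Series notes, cytotoxicity.

Compound 1 `Cc1ccc(-c2nn(-c3ccccc3)cc2CNc2ccccc2)cc1` was run in an ADME assay on MDBK cells (Bos taurus) for cytotoxicity, read by MTT assay, with a stated time of 72 h (a lower number here means that less compound is tolerated, a higher number that more compound is tolerated), and gives > 100000 nM, which is a limit of the assay and not a number. Compound 2 `Cc1ccc(NCc2cn(-c3ccccc3)nc2-c2ccc(Br)cc2)cc1` likewise gives > 100000 nM in this assay, again a limit. For the measured compounds named here, compound 3 `FC(F)(F)c1ccc(NCc2cn(-c3ccccc3)nc2-c2ccc(C(F)(F)F)cc2)cc1` is the one member with a number: in this assay compound 3 gives 26000 nM. Going by the values given here, compound 1 therefore stands at the limit of > 100000 nM in this assay, at which 2 of the 3 values shown sit; nothing places it on a scale against the others, and no step between measured compounds can be drawn from this set.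

The next compound, compound 4 `Cc1ccc(-c2nn(-c3ccccc3)cc2CNc2ccc(Cl)cc2)cc1`, differs from compound 1 by chloro in place of hydrogen on an aromatic carbon. Among the compounds with values here, no measured pair shows what chloro in place of hydrogen does here, so the step from compound 1 to compound 4 in this assay is expected to be small, within the usual scatter or only modestly toward less compound tolerated, as the estimate an at least 1.4-fold lower number from compound 1 to compound 4 (0.15 log units; that floor lies within the scatter) shows. For compound 4 in this assay the expected value is 70000 nM, with the range 30000 nM to 200000 nM, and a real chance that only a limit is again reported.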

Compound 4, half-maximal cytotoxic concentration: > 100000 nM
Compound 4 was reported as a limit (the forecaster's own chance of this, stated with the estimate: 50%); middle value at least 1.4-fold (0.15 log units) from the limit.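

In this assay compound 4 gives > 100000 nM, a limit and not a number. Compound 1 also stands at a limit, so no step from compound 1 to compound 4 can be read: the limit of > 100000 nM in this assay, at which 3 of the 4 values shown sit.

The compounds shown leave open what chloro in place of hydrogen does in this series.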